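Lengthening the chain on the ring nitrogen of compound 1

The source may hold more compounds than are shown below. What is called first, only, known or untested is meant among the compounds shown, and "the series" means these compounds.

Of the compounds shown here, three sharing one core have been measured in a physicochemical assay for solubility, measured as kinetic solubility; a lower number here means a less soluble compound, a higher number a more soluble compound. Compound 1 `Cc1cnc(NC(=O)c2cc(Oc3ccc(S(C)(=O)=O)cc3)c3cn(C)nc3c2)cn1` gives 454000 nM, the highest of the three numbers. Compound 2 `CCS(=O)(=O)c1ccc(Oc2cc(C(=O)Nc3cnc(C)cn3)cc3nn(C)cc23)cc1` gives 69000 nM, and compound 3 `Cc1cnc(NC(=O)c2cc(Oc3ccc(S(=O)(=O)N(C)C)cc3)c3cn(C)nc3c2)cn1` gives 134000 nM. The drop is a 6.6-fold lower number from compound 1 to compound 2 (0.82 log units; beyond the scatter) and a 3.4-fold lower number from compound 1 to compound 3 (0.53 log units; beyond the scatter), while a 1.9-fold higher number from compound 2 to compound 3 (0.29 log units; within the scatter).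

Compound 4 `CCCn1cc2c(Oc3ccc(S(C)(=O)=O)cc3)cc(C(=O)Nc3cnc(C)cn3)cc2n1` has not yet been measured. Compared with compound 1, it carries ethyl in place of hydrogen on a saturated chain carbon bound to an aromatic nitrogen. The closest guide among the measured steps is the step of a 6.6-fold lower number from compound 1 to compound 2 (0.82 log units; beyond the scatter), where a single carbon was added to a chain on the sulfonyl side; here two carbons are added to the chain on the ring nitrogen. Since the addition of a carbon produced a clear fall in that case, compound 4 is expected to be less soluble than compound 1 by a step at least as large, estimated as a 9.1-fold lower number from compound 1 to compound 4 (0.96 log units; beyond the scatter). The expected value for compound 4 is 50000 nM, within a range of 15000 nM to 200000 nM.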

Compound 4, solubility: 2300 nM
Beside the measured number, compound 4's estimate is 22-fold (1.34 log units) above it; the whole stated range lies above it.
By their numbers in this assay, from the lowest: compound 4; then compounds 2 and 3 (each within the scatter of the next); then compound 1.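

In this assay the change from methyl to propyl, on a saturated chain carbon bound to an aromatic nitrogen, gives a 200-fold lower number from compound 1 to compound 4 (2.30 log units; beyond the scatter). That step is far larger than a 6.6-fold lower number from compound 1 to compound 2 (0.82 log units; beyond the scatter), where the added carbon sits on a chain bound to a sulfonyl sulfur, so the number in this assay can move much further at the aromatic nitrogen than the sulfonyl changes alone suggested. Nothing shown here explains why the number falls so far at this position.

With only methyl and propyl shown on this nitrogen, it remains open whether an ethyl chain would give a number nearer that of compound 1 or that of compound 4. From the compounds shown here alone, it also remains open whether a propyl chain ending in a hydroxyl group or an amine would keep the number as low as that of compound 4.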